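A few compounds are considered here, and "the series" means these few. Any claim that something is new, unique, unknown or untested is made for them only; others in the source may bear on it.

Measured in a functional assay on SK-OV-3 cells (Homo sapiens) for inhibition, read by WST assay, with a stated time of 4 days; a lower number here means a stronger inhibitor, a higher number a weaker inhibitor:

- Compound 1 `CC[C@H](N)C(=O)N[C@H]1CCCC[C@H]2CC[C@@H](C(=O)NC(c3ccccc3)c3ccccc3)N2C1=O`: > 10000 nM (a limit of the assay, not a number)
- Compound 2 `CC[C@H](NC)C(=O)N[C@H]1CCCC[C@H]2CC[C@@H](C(=O)NC(c3ccccc3)c3ccccc3)N2C1=O`: 1000 nM

Within the data shown here, compound 2 holds the only true number in this assay, 1000 nM. Compound 1 stands at the limit of > 10000 nM in this assay, at which 1 of the 2 values shown sits.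

The next compound, compound 3 `C[C@H](O)C(=O)N[C@H]1CCCC[C@H]2CC[C@@H](C(=O)NC(c3ccccc3)c3ccccc3)N2C1=O`, has 1-hydroxyethyl in place of 1-(methylamino)propyl on a carbonyl carbon. The nitrogen of the 1-(methylamino)propyl group is therefore gone, and an oxygen stands in the new group.

Among the measured compounds shown here, only one measured step bears on this change. It is an at least 10-fold lower number from compound 1 to compound 2 (1.00 log units; beyond the scatter), made by putting methyl in place of hydrogen on that same amine nitrogen. A small edit at this nitrogen thus moved the number clearly, so replacing the whole group is expected to matter as well. The likely direction is towards a weaker inhibitor, since the methylated amine of compound 2 is lost.

The expected change is a 10-fold higher number from compound 2 to compound 3 (1.00 log units; beyond the scatter). Compound 3 is estimated at 10000 nM, with an expected range of 3000 nM to 30000 nM, and the assay may well report only a limit.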

Compound 3, half-maximal inhibitory concentration: > 10000 nM
Compound 3: no number, only a limit; the forecaster's own chance of this, stated with the estimate: 70%; the middle value sits exactly at the limit.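

In this assay compound 3 reads > 10000 nM, which is a limit of the assay and not a number. Putting 1-hydroxyethyl in place of 1-(methylamino)propyl on this carbonyl carbon gives an at least 10-fold higher number from compound 2 to compound 3 (1.00 log units; beyond the scatter), and since both groups count the same hydrogen-bond donors and acceptors, that count alone does not settle the result at this position. Compound 1 and compound 3 both stop at the limit, so the step between them cannot be read and neither can be placed ahead of the other: the limit of > 10000 nM in this assay, at which 2 of the 3 values shown sit.

The change to compound 3 alters two things at once, exchanging the methylamino part for a hydroxyl and shortening the chain, so the compounds shown cannot say which of these accounts for the step. A 1-hydroxypropyl group would keep the chain of compound 2 with the oxygen in place of the nitrogen, while a 1-(methylamino)ethyl group would keep the methylated amine on the shorter chain, and either would separate the two effects.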